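The compounds below may be only part of what the source reports. "The series", "measured", "known", "first", "only" and "open" are said of these compounds alone.

Among the measured compounds shown here, compound 1, with the structure `COC(=O)C1=C(Nc2ccc(OC)cc2)O/C(=C\c2c[nH]c3ncccc23)C1=O`, is one of two compounds measured in an ADME assay on microsomes from liver (Homo sapiens) for metabolic stability, read by LC-MS, using NADPH, with a stated time of 30 min, tested at 1 uM; a higher number here means that more of the compound is left, a lower number that less of the compound is left. In this assay compound 1 gives 33%, the lower of the two numbers. The other measured compound is compound 2, `COC(=O)C1=C(Nc2ccccc2Cl)O/C(=C\c2c[nH]c3ncccc23)C1=O`, which in this assay gives 67%. For the measured compounds named here, the only change between them is the 2-chlorophenyl in place of the 4-methoxyphenyl on the amine nitrogen, and that single change carries a step of a number 34 percentage points higher from compound 1 to compound 2 (beyond the scatter).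

Compound 3, `COC(=O)C1=C(Nc2ccccc2C)O/C(=C\c2c[nH]c3ncccc23)C1=O`, is not yet measured. It differs from compound 1 by 2-methylphenyl in place of 4-methoxyphenyl on an amine nitrogen. Going by the values given here, the one measured step that bears on this change is the one from compound 1 to compound 2: there, too, the 4-methoxyphenyl left the amine nitrogen and a ring bearing a single substituent at its 2-position entered, and the gain was large. Among the compounds with values here, no measured pair shows a 2-methylphenyl entering directly, so the size of the step can only be guessed from that one example. Compound 3 is therefore expected to gain over compound 1 in this assay, by an estimated a number 22 percentage points higher from compound 1 to compound 3 (beyond the scatter), and its value is estimated at 55%, within a range of 33% to 77%.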

Compound 3, percent of the compound remaining: 53%
Compound 3: middle estimate off by 2 percentage points, on the high side; measured number inside the range.
By their numbers in this assay, from the lowest: compound 1; then compound 3; then compound 2.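

In this assay, the gain seen with the 2-chlorophenyl group is not unique to that group: the 2-methylphenyl group in place of 4-methoxyphenyl on the amine nitrogen also gives a clear rise, namely a number 20 percentage points higher from compound 1 to compound 3 (beyond the scatter) in this pair. The group on the ring still matters, since methyl in place of chloro on an aromatic carbon gives a number 14 percentage points lower from compound 2 to compound 3 (beyond the scatter) and so gives back part of that gain. Across these three compounds, then, both ortho-free wording aside, the two replacements for 4-methoxyphenyl improve on compound 1 to different degrees, and nothing shown explains either step.

In this assay, the gain seen with the 2-chlorophenyl group is not unique to that group: replacing 4-methoxyphenyl on the amine nitrogen with 2-methylphenyl also gives a clear rise, with a number 20 percentage points higher from compound 1 to compound 3 (beyond the scatter) in this pair. The choice of group still matters, since methyl in place of chloro on an aromatic carbon gives a number 14 percentage points lower from compound 2 to compound 3 (beyond the scatter) and so gives back part of that gain. Both replacements therefore improve on compound 1, but to different degrees, and no measurement shown here explains either step.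

The compounds shown leave open whether the rise comes mainly from losing 4-methoxyphenyl or from what enters in its place, a question that plain phenyl, with no added group, or 4-chlorophenyl could help to settle. They also leave open how far the trend extends to other groups on the ring, such as fluoro, trifluoromethyl or a nitrile, or to a non-aromatic group such as cyclohexyl on the same amine nitrogen.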